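The source may report more compounds than this note shows. Statements on the series, on what has been measured and on what is new or still open speak of the compounds shown alone.

Measured so far in an ADME assay on HepG2 2.2.15 cells (Homo sapiens) for cytotoxicity, read by MTT assay; on this read-out higher numbers stand for lower toxicity in this test and lower numbers for higher toxicity in this test:
compound 1 `C=C1CC[C@@H]2[C@](C)(COC(=O)/C=C/c3cccc(Cl)c3)[C@H](O)CC[C@@]2(C)[C@@H]1/C=C/C1=CCOC1=O` gives 147000 nM.
compound 2 `C=C1CC[C@@H]2[C@](C)(COC(=O)c3cccs3)[C@H](O)CC[C@@]2(C)[C@@H]1/C=C/C1=CCOC1=O` gives 557000 nM.

Compound 1 therefore holds the lowest of the two numbers, meaning the greater toxicity on this read-out. Within the data shown here, the only step known here, a 3.8-fold higher number from compound 1 to compound 2 (0.58 log units; beyond the scatter), shows that exchanging the group on the carbonyl carbon can move the number beyond the scatter, towards lower toxicity. Compound 3 `C=C1CC[C@@H]2[C@](C)(COC(C)=O)[C@H](O)CC[C@@]2(C)[C@@H]1/C=C/C1=CCOC1=O` makes a different exchange at the same carbonyl carbon: methyl in place of 2-(3-chlorophenyl)ethenyl on a carbonyl carbon. Among the measured compounds shown here, since the one comparable exchange raised the number, a rise is expected here as well, estimated as a 2.7-fold higher number from compound 1 to compound 3 (0.43 log units; beyond the scatter). Compound 3 is thus expected to give about 400000 nM, within a range of 150000 nM to 1000000 nM.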

Compound 3, half-maximal cytotoxic concentration: 225000 nM
For compound 3 the middle estimate is 1.8-fold (0.25 log units) above the measured one, within the range that was stated.
By their numbers in this assay, from the lowest: compounds 1 and 3 (each within the scatter of the next); then compound 2.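

At this carbonyl carbon, this assay does not separate methyl from the far larger 2-(3-chlorophenyl)ethenyl, with a 1.5-fold higher number from compound 1 to compound 3 (0.18 log units; within the scatter). Thiophen-2-yl is the group that stands apart, with a 2.5-fold lower number from compound 2 to compound 3 (0.39 log units; beyond the scatter), so the earlier step does not show a general rise on losing 2-(3-chlorophenyl)ethenyl. No measurement shown here explains this difference. Going by these compounds, it remains open whether a longer chain, a phenyl ring or an amine at this carbon would group with compound 2 or with compound 1 and compound 3.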